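Fluoro to nitro on compound 2

A few compounds are considered here, and "the series" means these few. Any claim that something is new, unique, unknown or untested is made for them only; others in the source may bear on it.

Compound 1 `CNC(=O)c1ccccc1Oc1nc(Nc2ccc(C)cc2C)ncc1Br` gives 49600 nM
Compound 2 `Cc1cccc(Nc2ncc(Br)c(Oc3cccc(F)c3)n2)c1` gives 19400 nM
Compound 3 `Cc1cccc(Nc2ncc(Br)c(Oc3cc(Cl)cc(Cl)c3)n2)c1` gives > 50000 nM (a limit, not a number)

In a functional assay on U-937 cells (Homo sapiens) for antiproliferative activity, read by MTT assay, with a stated time of 24 h (a higher number here means a weaker inhibitor, a lower number a stronger inhibitor), compound 2 has the lower of the two actual numbers, and compound 1 at 49600 nM lies beyond the scatter from it. In this assay compound 3 gives only a limit, which is the limit of > 50000 nM in this assay, at which 1 of the 3 values shown sits.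

Compound 4 `Cc1cccc(Nc2ncc(Br)c(Oc3cccc([N+](=O)[O-])c3)n2)c1` differs from compound 2 in one place: nitro in place of fluoro on an aromatic carbon. This puts nitro in place of fluoro on an aromatic carbon, meta to a large group.

Going by the values given here, only one measured step bears on this change, and it is a different exchange: an at least 2.5-fold higher number from compound 2 to compound 3 (0.41 log units; beyond the scatter). Among the compounds with values here, with this single step as the guide, a slight lean toward a higher number is expected in this assay, but no step clearly beyond the scatter. The expected change is a 1.3-fold higher number from compound 2 to compound 4 (0.13 log units; within the scatter). For compound 4 the estimated value is 26000 nM, with an expected range from 11000 nM to 50000 nM.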

Compound 4, half-maximal inhibitory concentration: 51200 nM
For compound 4 the middle estimate is 2.0-fold (0.29 log units) below the measured one; measured number above the stated range.
By their numbers in this assay, from the lowest: compound 2; then compounds 1 and 4 (each within the scatter of the next).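

In this assay, exchanging fluoro for nitro on this aromatic carbon, with the rest of compound 2 left unchanged, gives a 2.6-fold higher number from compound 2 to compound 4 (0.42 log units; beyond the scatter). This is the first step shown that replaces the fluoro group alone, and it points the same way as the broader change to the 3,5-dichlorophenyl group, an at least 2.5-fold higher number from compound 2 to compound 3 (0.41 log units; beyond the scatter). The reading for compound 3 is a limit, not a number: the limit of > 50000 nM in this assay, at which 1 of the 4 values shown sits.

The compounds shown leave open how an amine, a methoxy group or a plain hydrogen on this aromatic carbon would read, and whether any replacement of fluoro there gives a lower number. They also cannot tell what about the nitro group accounts for its step, since only one replacement at this carbon can be read.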